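A few compounds are considered here, and "the series" means these few. Any claim that something is new, unique, unknown or untested is made for them only; others in the source may bear on it.

Measured so far in an ADME assay on liver (Sus scrofa) for metabolic stability, read by LC-MS, with a stated time of 1 h, tested at 10 uM; a lower number here means that less of the compound is left, a higher number that more of the compound is left:
- compound 1, `CCCCCCCCCCCCCCCC(=O)N[C@@H](CCCCNC(C)=O)C(=O)N[C@@H](CCC(=O)C=[N+]=[N-])C(=O)OC(C)C`: > 50%
- compound 2, `CC(=O)NCCCC[C@H](NC(=O)[C@@H]1Cc2ccccc2CN1C(C)=O)C(=O)N[C@@H](CCC(=O)C=[N+]=[N-])C(=O)OC(C)C`: 72%

In this assay compound 1 reports only a limit, > 50%, not a number; it sits at the limit of > 50% in this assay, at which 1 of the 2 values shown sits. Compound 2 gives 72% in this assay. Among the compounds with values here, no measured step exists here. The step from compound 1 to compound 3 is hydrogen in place of octyl on a saturated chain carbon, seven bonds along the chain from a carbonyl carbon; compound 3 is `CCCCCCCC(=O)N[C@@H](CCCCNC(C)=O)C(=O)N[C@@H](CCC(=O)C=[N+]=[N-])C(=O)OC(C)C`. With both values shown at the stable end, a change beyond the scatter in either direction is not expected for this step. Compound 3 is estimated at 65% in this assay, that is an expected step that the limit leaves unreadable from compound 1 to compound 3.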

Compound 3, percent of the compound remaining: < 50%
Compound 3 gave a limit, no number; the forecaster's own chance of this, stated with the estimate: 30%; at least 15 percentage points between middle value and limit.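

In this assay compound 3 gives a limit, not a number: the limit of < 50% in this assay, at which 1 of the 3 values shown sits. Compound 1 also gives a limit, not a number: the limit of > 50% in this assay, at which 1 of the 3 values shown sits. The change of hydrogen in place of octyl at this place on the saturated chain therefore reads as a number no higher from compound 1 to compound 3 (the limit leaves the size open), which gives a direction for this change but no size.

From the compounds shown here alone, how far apart the two compounds lie stays open. Also open, going by these compounds, is where an amine, a carboxylic acid or a longer chain in place of octyl would fall in this assay.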